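The compounds below may be only part of what the source reports. "The series", "measured", "known", "first", "only" and "open" are said of these compounds alone.

Values in a functional assay on HGC-27 cells (Homo sapiens) for inhibition, read by MTT assay, with a stated time of 72 h; on this read-out higher numbers stand for weaker inhibition and lower numbers for stronger inhibition:
compound 1 `Cc1cc(N2CC[C@@H](C)[C@@H](N(C)c3ncnc4[nH]ccc34)C2)n2ncnc2n1`: 11300 nM
compound 2 `CCCSc1nc2nc(C)cc(N3CC[C@@H](C)[C@@H](N(C)c4ncnc5[nH]ccc45)C3)n2n1`: 20900 nM
compound 3 `Cc1cc(N2CC[C@@H](C)[C@@H](N(C)c3ncnc4[nH]ccc34)C2)n2nc(SCc3nc4ccccc4[nH]3)nc2n1`: > 100000 nM

The figure for compound 3 is a limit of the assay, not a number; compound 3 sits at the limit of > 100000 nM in this assay, at which 1 of the 3 values shown sits. Within the three measured compounds, compound 3 therefore stands at the weak end of what this assay can report.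

Compound 4 `Cc1cc(N2CC[C@@H](C)[C@@H](N(C)c3ncnc4[nH]ccc34)C2)n2nc(SCCCc3ccccc3)nc2n1` is not yet measured. From compound 3 to compound 4 the change is phenethyl in place of 1H-benzimidazol-2-yl on a saturated chain carbon bound to a sulfur, so that (3-phenylpropyl)sulfanyl replaces ((1H-benzimidazol-2-yl)methyl)sulfanyl on the shared core.

Among the compounds with values here, the steps that bear on this are those along the sulfur-linked chain: a 1.8-fold higher number from compound 1 to compound 2 (0.27 log units; within the scatter), an at least 8.8-fold higher number from compound 1 to compound 3 (0.94 log units; beyond the scatter) and an at least 4.7-fold higher number from compound 2 to compound 3 (0.67 log units; beyond the scatter). A propylsulfanyl group thus kept the number near that of compound 1, while the benzimidazolyl-bearing chain pushed it out to the limit. Compound 4 carries a chain closer in kind to compound 2 than to compound 3, so a move back toward lower numbers in this assay is expected, though a result at the limit cannot be excluded. Expected, then, is an at least 1.6-fold lower number from compound 3 to compound 4 (0.22 log units; that floor lies within the scatter). Compound 4 is estimated at 60000 nM, within 20000 nM to 200000 nM.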

Compound 4, half-maximal inhibitory concentration: > 100000 nM
Compound 4: a limit, no number; the forecaster's own chance of this, stated with the estimate: 40%; middle value at least 1.6-fold (0.22 log units) from the limit.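

In this assay compound 4, like compound 3, stands at a limit of the assay and not at a number, so the step between them cannot be read: the limit of > 100000 nM in this assay, at which 2 of the 4 values shown sit.
Phenyl in place of hydrogen at the end of the propyl chain gives an at least 4.7-fold higher number from compound 2 to compound 4 (0.67 log units; beyond the scatter), and the whole (3-phenylpropyl)sulfanyl group in place of hydrogen on the aromatic carbon gives an at least 8.8-fold higher number from compound 1 to compound 4 (0.94 log units; beyond the scatter), whereas propylsulfanyl alone stayed within the scatter of the unsubstituted compound 1.
Reaching the limit at this position therefore does not require 1H-benzimidazol-2-yl, with its hydrogen-bond donor and acceptor: a chain ending in phenyl, with neither, also reaches it.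

Going by these compounds, whether a ring as such or the added chain length drives this stays open, and a plain hexyl chain on the sulfur would separate the two. Also open, on these data alone, is whether an amine or a carboxylic acid at the end of the propyl chain would stay near compound 2 in this assay.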